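From Sulfamoyl to Diethylsulfamoyl in a Rat Assay

A few compounds are considered here, and "the series" means these few. Any claim that something is new, unique, unknown or untested is made for them only; others in the source may bear on it.

In a functional assay on the whole organism (strain Sprague-Dawley) for inhibition, with Rattus norvegicus as the target, with a stated time of 10 min (a higher number here means that more compound is needed for the effect, a lower number that less compound is needed), compound 1 `CCOC(=O)c1ccc(OCC)c(-c2ncc(C(=O)OCC)c(=O)[nH]2)c1` gives 1 mg/kg, while compound 2 `CCOC(=O)c1cnc(-c2cc(S(N)(=O)=O)ccc2OCC)[nH]c1=O` gives 50 mg/kg, the higher of the two numbers. Within the data shown here, only one measured step connects them. That step, a 50-fold higher number from compound 1 to compound 2 (1.70 log units; beyond the scatter), is large and beyond the scatter, and it places sulfamoyl in place of ethoxycarbonyl on an aromatic carbon.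

Among the measured compounds shown here, compound 3 `CCOC(=O)c1cnc(-c2cc(S(=O)(=O)N(CC)CC)ccc2OCC)[nH]c1=O` retains the rest of compound 2 and alters only that sulfamoyl group: diethylamino in place of amino on a sulfonyl sulfur. In words, diethylamino stands in place of amino on a sulfonyl sulfur, turning sulfamoyl into diethylsulfamoyl. For the measured compounds named here, no measured step changes anything on the sulfonyl sulfur, so the evidence is indirect. Going by the values given here, the step of a 50-fold higher number from compound 1 to compound 2 (1.70 log units; beyond the scatter) shows only that the number in this assay can move a long way when the group on that aromatic carbon changes. A moderate move towards a lower number is therefore expected, recovering part of that gap but not all of it, though the direction remains uncertain. The expected change is a 3.3-fold lower number from compound 2 to compound 3 (0.52 log units; beyond the scatter). For compound 3 the estimate is 15 mg/kg, with an expected range of 3 mg/kg to 60 mg/kg.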

Compound 3, dose for 50% inhibition: 10 mg/kg
Beside the measured number, compound 3's estimate is 1.5-fold (0.18 log units) above it; measured number inside the range.
By their numbers in this assay, from the lowest: compound 1; then compound 3; then compound 2.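

Among these compounds, on the sulfonyl sulfur the number in this assay responds to what the sulfur carries: diethylamino in place of amino gives a 5.0-fold lower number from compound 2 to compound 3 (0.70 log units; beyond the scatter), the first measured change at this place, and it lies beyond the scatter. The aromatic carbon still favours the original group, however, since replacing ethoxycarbonyl with diethylsulfamoyl gives a 10-fold higher number from compound 1 to compound 3 (1.00 log units; beyond the scatter), so the diethyl substitution recovers only part of the gap left by sulfamoyl, and ethoxycarbonyl keeps the lowest number of the three groups on that carbon. Nothing measured in this set accounts for either shift, and the numbers alone record only their size and direction.

The compounds shown leave open whether methylamino or dimethylamino on the sulfonyl sulfur would fall nearer to amino or to diethylamino, and whether a longer chain such as dipropylamino would carry the number lower still or reverse the trend. They also leave open whether a carboxylic acid or a carboxamide on that aromatic carbon would come closer to ethoxycarbonyl than either sulfonyl group does.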